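This account rests on a few compounds, and the source may have more. Where it says the series, first, only, none or still open, it means among the compounds named here.

Measured compounds in a functional assay on WM 266-4 cells (Homo sapiens) for antiproliferative activity, read by MTT assay, with a stated time of 48 h; a lower number here means a stronger inhibitor, a higher number a weaker inhibitor:
compound 1 `Fc1ccc(C2=NN(c3nc(-c4ccc(Br)cc4)cs3)C(c3cccs3)C2)cc1` gives 220 nM
compound 2 `Fc1ccc(C2=NN(c3nc(-c4ccccc4)cs3)C(c3cccs3)C2)cc1` gives 170 nM
compound 3 `Cc1ccc(C2=NN(c3nc(-c4ccc(Br)cc4)cs3)C(c3cccs3)C2)cc1` gives 18400 nM

Compound 3 stands highest of the three numbers, set apart from compound 1 by the step of an 84-fold higher number from compound 1 to compound 3 (1.92 log units; beyond the scatter) and further still from compound 2.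

Compound 4 `Cc1ccc(C2=NN(c3nc(-c4ccccc4)cs3)C(c3cccs3)C2)cc1` differs from compound 3 by hydrogen in place of bromo on an aromatic carbon. For the measured compounds named here, the one measured step of the same kind, a 1.3-fold lower number from compound 1 to compound 2 (0.11 log units; within the scatter), lay within the scatter. On that basis the step of a 1.2-fold lower number from compound 3 to compound 4 (0.09 log units; within the scatter) is expected to stay within the scatter as well, with no clear direction. Compound 4 is therefore estimated at 15000 nM in this assay, with a range from 6000 nM to 40000 nM.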

Compound 4, half-maximal inhibitory concentration: 7520 nM
The estimate for compound 4 lay 2.0-fold (0.30 log units) above the measured number; the range from low to high includes it.
By their numbers in this assay, from the lowest: compounds 2 and 1 (each within the scatter of the next); then compound 4; then compound 3.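

Taking 4-bromophenyl to phenyl now gives a step beyond the scatter on the methyl-bearing core, a 2.4-fold lower number from compound 3 to compound 4 (0.39 log units; beyond the scatter), where the fluoro-bearing pair showed none, yet the two steps still agree: the same change on two cores in this assay, a 1.3-fold lower number (0.11 log units; within the scatter) from compound 1 to compound 2 and a 2.4-fold lower number (0.39 log units; beyond the scatter) from compound 3 to compound 4, 1.9-fold (0.28 log units) apart, within the scatter of two such steps

Methyl in place of fluoro stays large without the bromo, a 44-fold higher number from compound 2 to compound 4 (1.65 log units; beyond the scatter), so in these two pairs that gap does not depend on the bromo: the same change on two cores in this assay, an 84-fold higher number (1.92 log units; beyond the scatter) from compound 1 to compound 3 and a 44-fold higher number (1.65 log units; beyond the scatter) from compound 2 to compound 4, 1.9-fold (0.28 log units) apart, within the scatter of two such steps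

On these data alone, whether a chloro or a methoxy in place of the fluoro keeps the numbers of compound 1 and compound 2 or moves toward those of compound 3 and compound 4 stays open. So does the effect of an amine in place of the bromo.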